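A few compounds are considered here, and "the series" means these few. Any claim that something is new, unique, unknown or untested is made for them only; others in the source may bear on it.

In an assay on isolated protein for inhibition of alpha-ketoglutarate-dependent dioxygenase alkB homolog 3 (Homo sapiens), read by fluorescence, with stated times of 60 min and 15 min (on this read-out higher numbers stand for weaker inhibition and lower numbers for stronger inhibition), compound 1 `COc1cc(OC)cc(C2=C(Br)C(=O)c3ccc(C)cc32)c1` gives > 50000 nM, which is a limit of the assay and not a number. Compound 2 `COc1ccc(C2=C(Br)C(=O)c3ccc(C)cc32)cc1` gives 43200 nM in this assay. Compound 3 `Cc1ccc2c(c1)C(c1ccccc1)=C(Br)C2=O` gives > 50000 nM there, again a limit rather than a number. Going by the values given here, compound 3 thus stands at the limit, and the single measured step, an at least 1.1-fold higher number from compound 2 to compound 3 (0.06 log units; that floor lies within the scatter), has only a floor, because two of the three values sit at the limit of > 50000 nM in this assay, at which 2 of the 3 values shown sit. Compound 4 `Cc1ccc(C2=C(Br)C(=O)c3ccc(C)cc32)cc1` carries methyl in place of hydrogen on an aromatic carbon, a methyl in place of hydrogen on an aromatic carbon, para to a large group. Among the compounds with values here, no measured step covers this change, and the one step known is small. The step from compound 3 to compound 4 is expected to be a step that the limit leaves unreadable from compound 3 to compound 4, none beyond the scatter. Compound 4 is therefore estimated at 60000 nM, within 20000 nM to 200000 nM.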

Compound 4, half-maximal inhibitory concentration: > 50000 nM
Compound 4 was reported as a limit (the forecaster's own chance of this, stated with the estimate: 70%); the middle value is on the limit's open side.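

In this assay, methyl in place of methoxy on this aromatic carbon gives an at least 1.1-fold higher number from compound 2 to compound 4 (0.06 log units; that floor lies within the scatter), so this change shows no difference that can be told from the scatter. Methyl in place of hydrogen at the same place cannot be read, and compound 4 joins the compounds at the limit: the limit of > 50000 nM in this assay, at which 3 of the 4 values shown sit.

The compounds shown leave open how far above that limit compound 3 and compound 4 really lie. They also leave open whether an amine, a hydroxyl or a carboxylic acid at this place would give a value clearly lower than that of compound 2.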